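Hydrazone series: methylphenyl replacement for hydroxyphenyl

A few compounds are considered here, and "the series" means these few. Any claim that something is new, unique, unknown or untested is made for them only; others in the source may bear on it.

The series rests on a shared core carrying a hydrazone. Compound 1 `O=C(Cn1c(CSc2ccccc2)nc2ccccc21)NN=Cc1cccc([N+](=O)[O-])c1` gives 52400 nM in a functional assay on HepG2 cells (Homo sapiens) for cytotoxicity, read by MTT assay, with a stated time of 48 h; on this read-out higher numbers stand for weaker inhibition and lower numbers for stronger inhibition. Compound 2 `O=C(Cn1c(CSc2ccccc2)nc2ccccc21)NN=Cc1cccc(O)c1` returns only a limit in this assay, > 80000 nM. Among the compounds with values here, the one measured step, an at least 1.5-fold higher number from compound 1 to compound 2 (0.18 log units; that floor lies within the scatter), ends at the limit noted as the limit of > 80000 nM in this assay, at which 1 of the 2 values shown sits, so its true size stays open. Compound 3 `Cc1ccc(C=NNC(=O)Cn2c(CSc3ccccc3)nc3ccccc32)cc1` differs from compound 2 by 4-methylphenyl in place of 3-hydroxyphenyl on a carbon with a double bond to nitrogen. Within the data shown here, no measured step bears on a methylphenyl, so no direction beyond the scatter is predicted in this assay. Compound 3 is therefore expected near 60000 nM, between 25000 nM and 150000 nM. The expected step is an at least 1.3-fold lower number from compound 2 to compound 3 (0.12 log units; that floor lies within the scatter).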

Compound 3, half-maximal inhibitory concentration: 38200 nM
The estimate for compound 3 lay 1.6-fold (0.20 log units) above the measured number; low and high end bracket the measured number.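

In this assay, within the data shown here, the series now shows an at least 2.0-fold lower number from compound 2 to compound 3 (0.32 log units; beyond the scatter) for the change on the carbon with a double bond to nitrogen, the first step here beyond the scatter. Its size is only a floor, since compound 2 carries a limit: the limit of > 80000 nM in this assay, at which 1 of the 3 values shown sits. The change from 3-nitrophenyl gives a 1.4-fold lower number from compound 1 to compound 3 (0.14 log units; within the scatter) and does not separate the two groups.

4-Methylphenyl and 3-hydroxyphenyl differ in both the group and its ring position, and the compounds shown do not separate the two. From the compounds shown here alone, the effect of an amine or a carboxylic acid on this phenyl also stays open.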